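Acetyl in Place of Ethyl on the Pyrimidine Amine

A few compounds are considered here, and "the series" means these few. Any claim that something is new, unique, unknown or untested is made for them only; others in the source may bear on it.

compound 1 `CCNc1cc(Oc2ccc(NC(=O)Nc3cccc(C(F)(F)F)c3)cc2)ncn1` — 25 nM
compound 2 `CNc1cc(Oc2ccc(NC(=O)Nc3ccccc3)cc2)ncn1` — 6300 nM
compound 3 `CNc1cc(Oc2ccc(NC(=O)Nc3cccc(C(F)(F)F)c3)cc2C)ncn1` — <= 10 nM

Three compounds share one core and were tested in an assay on isolated protein for inhibition of serine/threonine-protein kinase TNNI3K (Homo sapiens); a higher number here means a weaker inhibitor, a lower number a stronger inhibitor. Compound 1 gives 25 nM, the lower of the two plain numbers; compound 2, which lacks the trifluoromethyl group, gives 6300 nM, a gap far beyond the usual scatter. Compound 3 sits at <= 10 nM, which is a limit of the assay and not a number (the limit of <= 10 nM in this assay, at which 1 of the 3 values shown sits).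

The next compound, compound 4 `CC(=O)Nc1cc(Oc2ccc(NC(=O)Nc3cccc(C(F)(F)F)c3)cc2)ncn1`, differs from compound 1 in one place: acetyl in place of ethyl on a nitrogen on an aromatic ring. For the measured compounds named here, no measured pair shows this change, so its size is uncertain. The expected step in this assay is a 4.0-fold higher number from compound 1 to compound 4 (0.60 log units; beyond the scatter), toward weaker inhibition. The estimate for compound 4 is 100 nM, with a range from 20 nM to 800 nM.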

Compound 4, half-maximal inhibitory concentration: 20 nM
Compound 4: the middle estimate sits 5.0-fold (0.70 log units) above what was measured; measured number inside the range.
By their numbers in this assay, from the lowest: compounds 4 and 1 (each within the scatter of the next); then compound 2. At a limit, below all of these: compound 3.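

On a nitrogen on an aromatic ring, acetyl in place of ethyl gives a 1.3-fold lower number from compound 1 to compound 4 (0.10 log units; within the scatter) in this assay. This position can therefore carry either group, including the carbonyl oxygen and the hydrogen-bond acceptor that acetyl adds, with no readable difference in this assay. Nothing measured here bears on why the two groups read alike. Still open, as far as these compounds go, is how a longer chain, a carboxylic acid or a sulfonamide on this nitrogen would read. Also open, from the compounds shown here alone, is whether this same exchange would read alike with other groups elsewhere on the shared core.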